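Chloro-for-hydroxyl swap on the pyrazoline aryl group

The source may hold more compounds than are shown below. What is called first, only, known or untested is meant among the compounds shown, and "the series" means these compounds.

Compounds measured in a functional assay on cells (Cancer cell lines, Homo sapiens) for cytotoxicity, read by sulforhodamine B assay, with a stated time of 48 h; a lower number here means a stronger inhibitor of growth, a higher number a weaker inhibitor of growth:
compound 1 `O=C1N=C(N2N=C(c3ccccc3)CC2c2ccccc2O)S/C1=C1/C(=O)Nc2ccccc21` gives 4770 nM;
compound 2 `O=C1N=C(N2N=C(c3ccccc3)CC2c2ccccc2O)S/C1=C1/C(=O)Nc2ccc(Br)cc21` gives 800 nM;
compound 3 `COc1ccc(C2CC(c3ccc4ccccc4c3)=NN2C2=NC(=O)/C(=C3\C(=O)Nc4ccccc43)S2)cc1` gives 32800 nM.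

Compound 1 stands second highest of the three numbers in this assay. Its nearest neighbour is compound 2, reached by a 6.0-fold lower number from compound 1 to compound 2 (0.78 log units; beyond the scatter), a bromo in place of hydrogen on an aromatic carbon. Its furthest is compound 3, which differs from compound 1 in more than one place, so only the two values themselves can be compared: compound 3 gives the highest number of the set.

Compound 4 `O=C1N=C(N2N=C(c3ccccc3)CC2c2ccc(Cl)cc2)S/C1=C1/C(=O)Nc2ccccc21` is not yet measured. It differs from compound 1 by 4-chlorophenyl in place of 2-hydroxyphenyl on a saturated ring carbon. Among the measured compounds shown here, no measured step touches this position: the only single-point step in the set, from compound 1 to compound 2, alters the other aromatic ring, and compound 3 carries two changes at once. Nothing in the data points to a direction here, so a step within the scatter, or at most a modest one either way, is expected: a 1.3-fold higher number from compound 1 to compound 4 (0.10 log units; within the scatter). Compound 4 is therefore estimated at 6000 nM, with a range from 1500 nM to 25000 nM.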

Compound 4, concentration for total growth inhibition: 910 nM
The estimate for compound 4 lay 6.6-fold (0.82 log units) above the measured number, and the stated range ends above it.
By their numbers in this assay, from the lowest: compounds 2 and 4 (each within the scatter of the next); then compound 1; then compound 3.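

In this assay the saturated ring carbon proves to be a position that responds: 4-chlorophenyl in place of 2-hydroxyphenyl gives a 5.2-fold lower number from compound 1 to compound 4 (0.72 log units; beyond the scatter) at a place the earlier bromo step did not touch. The hydroxyl is thus not required for a number of this size, since the entering group has 0 hydrogen-bond donors and 0 hydrogen-bond acceptors and the number still falls. No measurement shown here accounts for the step.

Going by these compounds, the change alters both the substituent and its place on the phenyl ring, so it remains open whether the step follows from adding the chlorine, losing the hydroxyl or moving the substituent, which unsubstituted phenyl, 2-chlorophenyl and 4-hydroxyphenyl at this carbon would help separate. Also open, on these data alone, is how an amine or a carboxylic acid on this phenyl ring would read.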